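Lengthening the Selenoether Chain on Compound 1

The compounds below may be only part of what the source reports. "The series", "measured", "known", "first", "only" and "open" are said of these compounds alone.

Compound 1 `C[Se]c1nc(N)c2ccccc2n1` is one of three measured members of a shared core. In a functional assay on CCRF-CEM cells (Homo sapiens) for cytotoxicity, read by MTT assay, with a stated time of 72 h (a higher number here means a weaker inhibitor of growth, a lower number a stronger inhibitor of growth), compound 1 gives only a limit, > 100000 nM, so its standing on the numbers shown is an open range rather than a point. Compound 3 `C[Se]c1nc([Se]C)c2ccccc2n1` gives 54900 nM in this assay, and compound 2 `CSc1nc(NCCCc2ccccc2)c2ccccc2n1` gives 87800 nM. For the measured compounds named here, the single one-place step among them, an at least 1.8-fold lower number from compound 1 to compound 3 (0.26 log units; that floor lies within the scatter), rests on the limit of > 100000 nM in this assay, at which 1 of the 3 values shown sits, and so cannot be told apart from the scatter. Compound 2 differs from compound 1 in more than one place, and its value can only be set alongside what compound 1 shows.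

Compound 4 `CCCCC[Se]c1nc(N)c2ccccc2n1` is not yet measured. It differs from compound 1 by butyl in place of hydrogen on a saturated chain carbon bound to a selenium atom. Going by the values given here, no measured step changes a chain in this way; the only step available, that between compound 1 and compound 3, exchanges an amino group for methylselanyl and gave a step no larger than the scatter. With nothing beyond the limit of compound 1 to lean on, for compound 4 the step of an at least 1.6-fold lower number from compound 1 to compound 4 (0.22 log units; that floor lies within the scatter) is expected to be small, if any, and the number may once more come back as a limit. Compound 4 is therefore estimated at 60000 nM, within 20000 nM to 200000 nM.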

Compound 4, concentration for total growth inhibition: 68000 nM
Compound 4: the middle estimate sits 1.1-fold (0.05 log units) below what was measured; the measured number falls inside the stated range.
By their numbers in this assay, from the lowest: compounds 3, 4 and 2 (each within the scatter of the next). At a limit, above all of these: compound 1.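

For the compounds shown here, with the amino group kept, compound 4 is the first compound here in which the chain on the selenium atom changes, from methyl to pentyl, and in this assay this change brings a number rather than a limit. Compound 1 remains a limit, > 100000 nM. The step, an at least 1.4-fold lower number from compound 1 to compound 4 (0.16 log units; that floor lies within the scatter), can therefore be read only as a floor, so the data show that the pentyl chain gives a measurable number but not that it moves the value beyond the scatter, and this reading rests on a limit: the limit of > 100000 nM in this assay, at which 1 of the 4 values shown sits.

From the compounds shown here alone, what an ethyl or propyl chain, or a chain longer than pentyl such as octyl, would give on the selenium atom remains open, as does whether a benzyl group there would give a number like that of compound 4. Also open, going by these compounds, are the true size of the step from the methyl chain to the pentyl chain and whether a sulfur atom in place of the selenium atom of compound 4 would change the number.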